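Swapping a Phenyl for a Methyl on a Weak Series

The source may report more compounds than this note shows. Statements on the series, on what has been measured and on what is new or still open speak of the compounds shown alone.

Of the compounds shown here, three sharing one core have been tested in a functional assay for inhibition, with Homo sapiens as the target; on this read-out higher numbers stand for weaker inhibition and lower numbers for stronger inhibition. Compound 1 `CCCCc1nnc(O)n2c(CCC)nc(C)c12` carries a butyl group on an aromatic carbon; in this assay compound 1 reaches only the limit of the assay, > 48000 nM. Compound 2 `CCCc1nc(C)c2cnnc(O)n12` has hydrogen in place of that butyl; in this assay compound 2 gives 56800 nM. Compound 3 `CCCc1nc(C)c2c(-c3ccccc3)nnc(O)n12` has phenyl in place of the butyl; in this assay compound 3 also sits at the limit, > 48000 nM. Compound 3 therefore cannot be placed on the numbers shown, and one further value shown is likewise only a limit. None of the steps among these three can be read in size, since a step that the limit leaves unreadable from compound 1 to compound 2, a step that the two limits leave unreadable from compound 1 to compound 3 and a step that the limit leaves unreadable from compound 2 to compound 3 all run into (the limit of > 48000 nM in this assay, at which 2 of the 3 values shown sit).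

Compound 4 `CCCc1nc(C)c2c(C)nnc(O)n12` differs from compound 3 in one place: methyl in place of phenyl on an aromatic carbon. Within the data shown here, no measured step gives a readable size for a change of this kind, and every measured value sits at or near the limit. Nothing in the data points to a step beyond the scatter, so compound 4 is expected to stay in the same weak range, with a step that the limit leaves unreadable from compound 3 to compound 4 as the expected step. The estimate for compound 4 in this assay is 55000 nM, within a range from 20000 nM to 200000 nM, with a fair chance that the assay again reports only a limit.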

Compound 4, half-maximal inhibitory concentration: 14000 nM
Beside the measured number, compound 4's estimate is 3.9-fold (0.59 log units) above it; the whole stated range lies above it.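

In this assay, the position para to a hydroxy group now yields readable steps, and all of them favour methyl: swapping phenyl for methyl gives an at least 3.4-fold lower number from compound 3 to compound 4 (0.53 log units; beyond the scatter), while swapping hydrogen for methyl gives a 4.1-fold lower number from compound 2 to compound 4 (0.61 log units; beyond the scatter). Cutting the butyl chain of compound 1 down to methyl gives an at least 3.4-fold lower number from compound 1 to compound 4 (0.53 log units; beyond the scatter), so methyl stands apart from all three other groups seen at this position, although these steps remain modest and compound 4 still needs 14000 nM. Smaller is not simply better here, since compound 2, with only hydrogen at this position, goes against that pattern and has the higher number of the two.

The steps among compounds 1, 2 and 3 still cannot be read, so those three groups cannot be ranked against one another: the limit of > 48000 nM in this assay, at which 2 of the 4 values shown sit.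

Going by these compounds, whether an ethyl group, a cyclopropyl ring or an amine at this position would lower the number further than methyl stays open, as does whether the advantage of methyl would hold with other groups elsewhere on the shared core.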